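The compounds below may be only part of what the source reports. "The series", "measured", "known", "first", "only" and "open" are said of these compounds alone.

Compound 3 `COc1ccc(C2CC(c3cc(Cl)c(C)cc3O)=NN2c2ccc(S(N)(=O)=O)cc2)cc1OC` gives 3980 nM in a functional assay on A498 cells (Homo sapiens) for antiproliferative activity, with a stated time of 48 h (on this read-out higher numbers stand for weaker inhibition of growth and lower numbers for stronger inhibition of growth), and so holds the lowest of the three numbers measured, though its gap to compound 1 is within the scatter. Compound 1 `Cc1cc(O)c(C2=NN(c3ccc(S(N)(=O)=O)cc3)C(c3ccccc3Cl)C2)cc1Cl` gives 5010 nM in this assay, and compound 2 `Cc1cc(O)c(C2=NN(c3ccc(S(N)(=O)=O)cc3)C(/C=C/c3ccccc3)C2)cc1Cl` gives 14900 nM. The steps between them are a 1.3-fold lower number from compound 1 to compound 3 (0.10 log units; within the scatter), a 3.7-fold lower number from compound 2 to compound 3 (0.57 log units; beyond the scatter) and a 3.0-fold higher number from compound 1 to compound 2 (0.47 log units; beyond the scatter). Compound 4 `COc1ccc(C2CC(c3cc(Cl)c(C)cc3O)=NN2c2ccc(S(N)(=O)=O)cc2)c(OC)c1OC` differs from compound 3 by methoxy in place of hydrogen on an aromatic carbon. Within the data shown here, no measured step adds a single group to the aryl ring on the saturated carbon; the measured steps swap that whole group, so they bear only loosely. The step from compound 3 to compound 4 is therefore expected to be a 1.1-fold lower number from compound 3 to compound 4 (0.06 log units; within the scatter), within the scatter. Compound 4 is expected to give 3500 nM, in the range 1200 nM to 10000 nM.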

Compound 4, concentration for 50% growth inhibition: 4150 nM
Beside the measured number, compound 4's estimate is 1.2-fold (0.07 log units) below it; the range from low to high includes it.
By their numbers in this assay, from the lowest: compounds 3, 4 and 1 (each within the scatter of the next); then compound 2.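

In this assay, methoxy in place of hydrogen, ortho to a large group, gives a 1.0-fold higher number from compound 3 to compound 4 (0.02 log units; within the scatter), so this single addition to the aryl ring on the saturated carbon leaves the read-out unmoved. Among the swaps of that whole group, 2,3,4-trimethoxyphenyl gives a 1.2-fold lower number from compound 1 to compound 4 (0.08 log units; within the scatter) and a 3.6-fold lower number from compound 2 to compound 4 (0.56 log units; beyond the scatter), leaving 2-phenylethenyl as the group set apart beyond the scatter. Nothing available explains this result. Going by these compounds, whether an amine or a carboxylic acid at this aromatic carbon would shift the number stays open, as does whether methoxy would behave alike on the 2-chlorophenyl ring.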